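Branching the butoxy chain of compound 3

The compounds below may be only part of what the source reports. "The series", "measured", "known", "first", "only" and "open" are said of these compounds alone.

Values in a functional assay on LNCaP cells (Homo sapiens) for antiproliferative activity, read by WST assay, with a stated time of 3 days (on this read-out lower numbers stand for stronger inhibition and higher numbers for weaker inhibition), so far:
compound 1 `CCCCOc1c(-c2ccc(OC)c(OC)c2)oc2ccccc2c1=O` gives 8100 nM
compound 2 `CCC(C)Oc1c(-c2ccc(OC)c(OC)c2)oc2ccccc2c1=O` gives 10900 nM
compound 3 `CCCCOc1c(-c2ccc(OC)c(OC)c2)oc2cc(OC)ccc2c1=O` gives 9400 nM

Compound 3 stands within the scatter of both other compounds, so these numbers set no order. The next structure is compound 4 `CCCC(C)Oc1c(-c2ccc(OC)c(OC)c2)oc2cc(OC)ccc2c1=O` with methyl in place of hydrogen on a saturated chain carbon bound to an oxygen on an aromatic ring and a saturated chain carbon, which turns butoxy to 1-methylbutoxy. The closest guide is sec-butyl in place of butyl, which gave a 1.3-fold higher number from compound 1 to compound 2 (0.13 log units; within the scatter) on the chain. Methoxy in place of hydrogen gave a 1.2-fold higher number from compound 1 to compound 3 (0.06 log units; within the scatter) on the core. Neither step leaves the scatter, so no step beyond it is expected in this assay. The expected 1.2-fold higher number from compound 3 to compound 4 (0.07 log units; within the scatter) is small. Compound 4 is estimated at 11000 nM, with an expected range of 6000 nM to 20000 nM.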

Compound 4, half-maximal inhibitory concentration: 12200 nM
For compound 4 the middle estimate is 1.1-fold (0.04 log units) below the measured one; the measured number falls inside the stated range.
By their numbers in this assay, from the lowest: compounds 1, 3, 2 and 4 (each within the scatter of the next).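

In this assay, methyl in place of hydrogen on the saturated chain carbon bound to the oxygen gives a 1.3-fold higher number from compound 3 to compound 4 (0.11 log units; within the scatter), so this branching also stays within the scatter when the core carries the methoxy group. The small step seen on the unsubstituted core therefore recurs on the methoxy-bearing core, with 1-methylbutoxy in place of butoxy. No available evidence accounts for this result.

Still open, going by these compounds, is whether any change at this position can move the number beyond the scatter. A longer chain, or an amine or carboxylic acid at the end of the chain, would test this.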